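The source may report more compounds than this note shows. Statements on the series, on what has been measured and on what is new or still open speak of the compounds shown alone.

Measured so far:
- compound 1, `COc1cccc(Cc2ccc3ccccc3c2O)c1`, in an assay on RBL-1 cells with Polyunsaturated fatty acid 5-lipoxygenase (Rattus norvegicus) as the target (on this read-out lower numbers stand for stronger inhibition and higher numbers for weaker inhibition), compound 1 gives 110 nM
- compound 2, `Oc1c(Cc2cccc(Oc3ccccc3)c2)ccc2ccccc12`, in this assay compound 2 gives 83 nM

Among the compounds with values here, compound 2 holds the lowest of the two numbers in this assay, but its only neighbour is compound 1, and the pair sits within the scatter. Within the data shown here, the one step among the measured compounds, a 1.3-fold lower number from compound 1 to compound 2 (0.12 log units; within the scatter), swaps a phenyl for a methyl on an oxygen on an aromatic ring and changes the number by no more than repeated measurement would.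

Compound 3, `Oc1c(Cc2cccc(Cl)c2)ccc2ccccc12`, is not yet measured. The change is chloro in place of phenoxy on an aromatic carbon; in words, a chloro in place of a phenoxy on an aromatic carbon, meta to a large group. Among the measured compounds shown here, no measured step replaces a group on that carbon with a single atom, so the step from compound 1 to compound 2 bears on it only loosely: it shows that the size of the group on that oxygen mattered little in this assay. The expectation is therefore a small step, or none beyond the scatter, for compound 3, expressed as a 1.4-fold higher number from compound 2 to compound 3 (0.16 log units; within the scatter). Compound 3 is estimated at 120 nM, with a range from 40 nM to 400 nM.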

Compound 3, half-maximal inhibitory concentration: 52 nM
The estimate for compound 3 lay 2.3-fold (0.36 log units) above the measured number; the measured number falls inside the stated range.
By their numbers in this assay, from the lowest: compounds 3, 2 and 1 (each within the scatter of the next, the first and the last beyond it).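

In this assay, this aromatic carbon tolerates a very wide range of group sizes: a 1.6-fold lower number from compound 2 to compound 3 (0.20 log units; within the scatter) replaces phenoxy, with its seven heavy atoms and its ring, by a single chlorine atom, and the change stays within the scatter. Within the data shown here, the other new comparison gives the first step that lies beyond the scatter, though only a modest one: a 2.1-fold lower number from compound 1 to compound 3 (0.33 log units; beyond the scatter) comes from chloro in place of methoxy, and it shows that an oxygen on this carbon, present in both compound 1 and compound 2, is not needed for a number at this level. No available data explain why the numbers behave this way.

From the compounds shown here alone, what remains open is whether this carbon needs any group at all, since a plain hydrogen there would separate the effect of having a group from the effect of which group it is. Going by these compounds, it is also open whether this tolerance extends to an amine or a carboxylic acid, which would carry a charge-forming group into the same place, unlike the three groups compared so far.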